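The compounds below may be only part of what the source reports. "The series", "measured", "known", "first", "only" and "open" are said of these compounds alone.

Measured in the series:
compound 1 `Cc1nnc(-c2nsc3ccccc23)o1` — in a functional assay on the whole organism for inhibition, with Rattus norvegicus as the target, with a stated time of 3.5 h, at a dose of 100 mg/kg by the intraperitoneal route (on this read-out lower numbers stand for less inhibition and higher numbers for more inhibition at the one dose given (going by the name of the read-out)), compound 1 gives 42%
compound 2 `c1ccc(-c2nnc(-c3nsc4ccccc34)o2)cc1` — in this assay compound 2 gives 48%
compound 3 `Clc1ccc(-c2nnc(-c3nsc4ccccc34)o2)cc1` — in this assay compound 3 gives 33%

Compound 3 carries the lowest of the three numbers in this assay. Going by the values given here, only one step separates it clearly from the others: a number 15 percentage points lower from compound 2 to compound 3 (beyond the scatter). Against compound 1 the gap is a number 9 percentage points lower from compound 1 to compound 3 (within the scatter), and compound 1 and compound 2 sit within the scatter of each other, a number 6 percentage points higher from compound 1 to compound 2 (within the scatter).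

Compound 4 `CCNc1nnc(-c2nsc3ccccc23)o1` differs from compound 3 in one place: ethylamino in place of 4-chlorophenyl on an aromatic carbon. Among the compounds with values here, no measured step puts an ethylamino group onto the shared core, so the only guidance is indirect. The step of a number 9 percentage points lower from compound 1 to compound 3 (within the scatter) shows that trading methyl for 4-chlorophenyl on this carbon moved the number by no more than the scatter, and a number 6 percentage points higher from compound 1 to compound 2 (within the scatter) shows the same for phenyl. The removal of the 4-chlorophenyl in compound 4 is therefore expected to move the number in this assay back toward the level of compound 1 at most, a step of a number 9 percentage points higher from compound 3 to compound 4 (within the scatter) that is not expected to exceed the scatter. Compound 4 is estimated at 42%, within 25% to 60%.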

Compound 4, a percentage reported as inhibition, in the whole organism at one dose (the size of the read-out at that dose, not a potency): 42%
For compound 4 middle estimate and measured number coincide at the digits printed; the range from low to high includes it.
By their numbers in this assay, from the lowest: compounds 3, 1, 4 and 2 (each within the scatter of the next, the first and the last beyond it).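

Among the compounds shown, only compound 4 places a ring-free, nitrogen-linked group with a hydrogen-bond donor on this carbon, and in this assay every exchange involving it stays within the scatter: a number 9 percentage points higher from compound 3 to compound 4 (within the scatter) and a number 6 percentage points lower from compound 2 to compound 4 (within the scatter) and no change at the digits printed from compound 1 to compound 4 (within the scatter). On this carbon, ethylamino therefore cannot be told apart by this read-out from methyl, phenyl or 4-chlorophenyl, although the step from phenyl to 4-chlorophenyl remains beyond the scatter. Nothing available here explains these numbers.

As far as these compounds go, whether a longer chain on the nitrogen, a dimethylamino group or a carboxylic acid on this carbon would move the number beyond the scatter stays open. The read-out gives the size of the effect at one dose, so the relative potency of these compounds also stays open.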